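The compounds below may be only part of what the source reports. "The series", "measured", "known", "first", "only" and "open" are said of these compounds alone.

Measured compounds:
compound 1 `Oc1cccc(-c2cc(-c3cccs3)cc(-c3cccc(O)c3)n2)c1`, 3480 nM
compound 2 `Oc1cccc(-c2cc(-c3ccco3)cc(-c3cccc(O)c3)n2)c1`, 1890 nM
compound 3 `Oc1ccc(-c2cc(-c3ccco3)cc(-c3cccc(O)c3)n2)cc1`, 840 nM

The three compounds were tested in a functional assay on HCT-15 cells (Homo sapiens) for cytotoxicity, read by CCK-8 assay; a higher number here means a weaker inhibitor, a lower number a stronger inhibitor. Among them compound 2 gives the second highest of the three numbers. Its nearest neighbour is compound 1, and the step of a 1.8-fold lower number from compound 1 to compound 2 (0.27 log units; within the scatter) lies within the scatter, so the two cannot be told apart. The step of a 2.3-fold lower number from compound 2 to compound 3 (0.35 log units; beyond the scatter) is beyond the scatter, if modest, so compound 3 gives the clearest lower number of the set.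

Compound 4 `Oc1cccc(-c2cc(-c3ccoc3)cc(-c3cccc(O)c3)n2)c1` has not yet been measured. It differs from compound 2 in one place: furan-3-yl in place of furan-2-yl on an aromatic carbon. Among the measured compounds shown here, only one measured step touches the same five-membered ring on the shared core, a 1.8-fold lower number from compound 1 to compound 2 (0.27 log units; within the scatter), and that step stayed within the scatter. The step of a 2.3-fold lower number from compound 2 to compound 3 (0.35 log units; beyond the scatter) concerns a different part of the core and does not bear on this change. Nothing measured shows what moving the point of attachment within the furan ring does.

On that basis the step of a 1.0-fold higher number from compound 2 to compound 4 (0.00 log units; within the scatter) is expected to stay within the scatter, in no clear direction. Compound 4 is therefore estimated to give about 1900 nM in this assay, with a range from 750 nM to 4800 nM.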

Compound 4, half-maximal inhibitory concentration: 1020 nM
The estimate for compound 4 lay 1.9-fold (0.27 log units) above the measured number; measured number inside the range.
By their numbers in this assay, from the lowest: compounds 3, 4, 2 and 1 (each within the scatter of the next, the first and the last beyond it).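

Moving the point of attachment within the furan ring, at the position opposite the ring nitrogen, gives a 1.9-fold lower number from compound 2 to compound 4 (0.27 log units; within the scatter) in this assay and so produces no step that can be told from the scatter. Set against the thiophen-2-yl of compound 1, however, furan-3-yl gives a 3.4-fold lower number from compound 1 to compound 4 (0.53 log units; beyond the scatter) and this modest step is beyond the scatter, which the furan-2-yl of compound 2 did not reach against the same compound, so this position now shows a measurable, if small, response to the choice of five-membered ring. Nothing available explains this difference between the two furan isomers and the thiophen-2-yl group.

The compounds shown leave open how the number in this assay would respond at this position to thiophen-3-yl or to a group of another kind, such as an amine, a carboxylic acid or a longer alkyl chain. They also leave open whether furan-3-yl would keep its place in the series alongside the 4-hydroxyphenyl group of compound 3.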